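The source may hold more compounds than are shown below. What is called first, only, known or untested is meant among the compounds shown, and "the series" means these compounds.

Measured compounds:
compound 1, `C#CCOc1ccc(/C=C/C(=O)c2ccc([N+](=O)[O-])cc2)cc1`, 44%
compound 2, `O=C(/C=C/c1ccc(OCc2cn(Cc3ccccc3)nn2)cc1)c1ccc(Br)cc1`, 34%
compound 3, `COc1ccc(C(=O)/C=C/c2ccc(OCc3cn(Cc4ccccc4)nn3)cc2)cc1`, 70%

These three compounds were tested in a functional assay on MCF7 cells (Homo sapiens) for inhibition, read by MTT assay, with a stated time of 48 h, tested at 10 uM; a lower number here means less inhibition of growth, a higher number more inhibition of growth at the concentration tested. Among the three numbers, compound 3 stands highest: compound 1 lies nearest, and compound 2 lies furthest, both beyond the usual scatter. Among the compounds with values here, the only single-point step among the measured compounds is a number 36 percentage points higher from compound 2 to compound 3 (beyond the scatter), a change on the ketone side of the shared core.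

Compound 4, `COc1ccc(C(=O)/C=C/c2ccc(OCc3cn(Cc4ccccc4F)nn3)cc2)cc1`, differs from compound 3 in one place: fluoro in place of hydrogen on an aromatic carbon. Within the data shown here, this change sits on the benzyl group at the far end of the molecule, a part that none of the measured steps touches. The step from compound 2 to compound 3 concerns a different ring and so gives no direct guide here. Among the measured compounds shown here, with no measured step bearing on this change, the expectation is a step of a number 4 percentage points lower from compound 3 to compound 4 (within the scatter), that is, no change beyond the scatter. Compound 4 is therefore estimated at 66% in this assay, with a range from 46% to 84%.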

Compound 4, percent growth inhibition at one concentration: 32%
Compound 4: the middle estimate sits 34 percentage points above what was measured, outside the stated range (below it).
By their numbers in this assay, from the lowest: compounds 4, 2 and 1 (each within the scatter of the next, the first and the last beyond it); then compound 3.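

In this assay the benzyl group at the far end of the molecule proves sensitive to a very small change: going from benzyl to 2-fluorobenzyl gives a number 38 percentage points lower from compound 3 to compound 4 (beyond the scatter) on the addition of one fluorine atom. Within the data shown here, until now, the only measured step was on the ketone side of the shared core, a number 36 percentage points higher from compound 2 to compound 3 (beyond the scatter) and so this is the first sign that the far end matters as well. Nothing measured here explains the fall in growth inhibition.

With only hydrogen and fluoro shown on this ring, it remains open whether any group ortho to a large group would lower the number, or whether this is particular to fluoro. A chloro group or an amine at this place, or a fluoro elsewhere on the ring, would help to separate these possibilities.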